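This account rests on a few compounds, and the source may have more. Where it says the series, first, only, none or still open, it means among the compounds named here.

Measured in a functional assay on MDA-MB-231 cells (Homo sapiens) for antiproliferative activity, read by MTT assay, with a stated time of 72 h; on this read-out higher numbers stand for weaker inhibition and lower numbers for stronger inhibition:
- Compound 1 `COc1cccc(S(=O)(=O)Nc2cccc(-c3nc(-c4ccc(NC(=O)c5cccnc5)cc4Cl)no3)c2)c1`: > 10000 nM
- Compound 2 `Cc1ccc(NC(=O)Nc2cccc(-c3nc(-c4ccc(NC(=O)c5cccnc5)cc4Cl)no3)c2)cc1`: 3500 nM

The entry for compound 1 is a limit, not a number. For the measured compounds named here, compound 2, at 3500 nM, therefore holds the only true number so far. Compound 3 `O=C(Nc1ccc(NS(=O)(=O)C2CC2)cc1)Nc1cccc(-c2nc(-c3ccc(NC(=O)c4cccnc4)cc3Cl)no2)c1` differs from it by (cyclopropylsulfonyl)amino in place of methyl on an aromatic carbon, para to a large group. Going by the values given here, the one measured step, an at least 2.8-fold lower number from compound 1 to compound 2 (0.45 log units; beyond the scatter), lies elsewhere, on a nitrogen on an aromatic ring, so it offers only a rough guide to size. A modest step towards stronger inhibition in this assay is expected, though its direction remains uncertain. The estimated change is a 1.4-fold lower number from compound 2 to compound 3 (0.15 log units; within the scatter). For compound 3 the expected value is 2500 nM, with an estimated range from 400 nM to 10000 nM.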

Compound 3, half-maximal inhibitory concentration: 300 nM
For compound 3 the middle estimate is 8.3-fold (0.92 log units) above the measured one, and the stated range ends above it.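

This aromatic carbon, para to a large group, accepts far more than methyl: in this assay the change to (cyclopropylsulfonyl)amino gives a 12-fold lower number from compound 2 to compound 3 (1.07 log units; beyond the scatter) and stands as the first step measured at this position. The earlier step lay on a nitrogen on an aromatic ring, so only now is this position seen to move the read-out strongly. Nothing given here accounts for the size of this gain. Going by these compounds, it remains open whether the three-membered ring is needed, and how (methylsulfonyl)amino, a simple amine or a carboxylic acid on this carbon would compare.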